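The source may hold more compounds than are shown below. What is called first, only, known or untested is meant among the compounds shown, and "the series" means these compounds.

Measured so far in an assay on isolated protein for inhibition of squalene synthase (Rattus norvegicus); a lower number here means a stronger inhibitor, a higher number a weaker inhibitor:
- compound 1, `CC(C)=CCC/C(C)=C/CC/C(C)=C/C[N+](C)(C)CCCS(=O)(=O)[O-]`, gives 200000 nM
- compound 2, `C[N+](C)(CCCCCCc1ccccc1)CCCCS(=O)(=O)[O-]`, gives 100000 nM

Compound 2 and compound 1 sit within the usual scatter of each other, so neither can be called the stronger inhibitor on these two numbers alone. Compound 3, `C[N+](C)(CCCCCCCCc1ccccc1)CCCCS(=O)(=O)[O-]`, differs from compound 2 in one place: phenethyl in place of phenyl on a saturated chain carbon, six bonds along the chain from an amine nitrogen. For the measured compounds named here, no measured pair shows this change, so a step of modest size is expected, at most on the edge of the scatter and if anything toward a lower number. For compound 3 the expected value in this assay is 60000 nM, within 15000 nM to 250000 nM, which would mean an estimated step of a 1.7-fold lower number from compound 2 to compound 3 (0.22 log units; within the scatter).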

Compound 3, half-maximal inhibitory concentration: 8000 nM
Compound 3: the middle estimate sits 7.5-fold (0.88 log units) above what was measured, outside the stated range (below it).
By their numbers in this assay, from the lowest: compound 3; then compounds 2 and 1 (each within the scatter of the next).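

In this assay, phenethyl in place of phenyl on this saturated chain carbon gives a 13-fold lower number from compound 2 to compound 3 (1.10 log units; beyond the scatter), a large step beyond the scatter. This shows that inhibition responds strongly to this change at this position, which the two earlier values could not reveal, as compound 1 and compound 2 differ in more than one place. Nothing available explains the size of this step. Still open, on these data alone, is whether phenylpropyl at the same place would give a lower number again or the trend would stop. Also open, as far as these compounds go, is whether a plain alkyl chain without the ring would do as well.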